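The source may hold more compounds than are shown below. What is called first, only, known or untested is meant among the compounds shown, and "the series" means these compounds.

Compound 1 `Cc1cc(-c2ccc(O)cc2)cn2c(CSCCc3ccccc3)cnc12`: in an ADME assay on HEL cells (Homo sapiens) for cytotoxicity, with a stated time of 3 days (a lower number here means that less compound is tolerated, a higher number that more compound is tolerated), compound 1 gives > 50 ug/mL, which is a limit of the assay rather than a number.
Compound 2 `Cc1cc(I)c2ncc(CSCCc3ccccc3)n2c1`: compound 2 gives > 50 ug/mL, again a limit.
Compound 3 `Cc1cc(-c2cccs2)c2ncc(CSCCc3ccccc3)n2c1`: compound 3 gives > 50 ug/mL, again a limit.

Compound 1 therefore stands nowhere definite within this assay; it sits at the same point as every other value shown, (the limit of > 50 ug/mL in this assay, at which 3 of the 3 values shown sit), and no ordering among the three compounds can be read. Compound 4 `Cc1cc(-c2ccccc2O)cn2c(CSCCc3ccccc3)cnc12` differs from compound 1 in one place: 2-hydroxyphenyl in place of 4-hydroxyphenyl on an aromatic carbon. Among the measured compounds shown here, the only step between measured compounds is a step that the two limits leave unreadable from compound 2 to compound 3, and it concerns a different exchange, so no measured step bears on the change from compound 1 to compound 4. With all three values at a limit, the expectation for compound 4 is no step beyond the scatter in this assay, in either direction, and most likely a limit again. Compound 4 is accordingly estimated at 50 ug/mL, with a range from 25 ug/mL to 100 ug/mL. This estimate implies an expected step of a number no higher from compound 1 to compound 4 (the limit leaves the size open).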

Compound 4, half-maximal cytotoxic concentration: > 50 ug/mL
Compound 4 was reported as a limit (the forecaster's own chance of this, stated with the estimate: 85%); the middle value lies on the limit itself.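

In this assay, the step from 4-hydroxyphenyl to 2-hydroxyphenyl cannot be read, as compound 1 and compound 4 both stand at a limit: the limit of > 50 ug/mL in this assay, at which 4 of the 4 values shown sit.

The compounds shown leave open what half-maximal cytotoxic concentration any of them actually has, and whether any two of them differ.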